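Acetamido to acetylpyrrolyl exchange on the saturated ring carbon

The source may report more compounds than this note shows. Statements on the series, on what has been measured and on what is new or still open speak of the compounds shown alone.

Measured compounds:
compound 1 `CC(=O)N[C@@H]1C[C@H]2O[C@@](C)([C@@H]1O)n1c3ccc(O)cc3c3c4c(c5c6ccccc6n2c5c31)C(=O)NC4` gives 8800 nM
compound 2 `CC(=O)N[C@@H]1C[C@H]2O[C@@](C)([C@@H]1O)n1c3ccccc3c3c4c(c5c6ccccc6n2c5c31)C(=O)NC4` gives 5200 nM

Both numbers come from a functional assay on K562 cells (Homo sapiens) for cytotoxicity, read by MTT assay, with a stated time of 48 h; a higher number here means a weaker inhibitor, a lower number a stronger inhibitor. Among the measured compounds shown here, of the two, compound 1 stands highest; the only measured step is a 1.7-fold lower number from compound 1 to compound 2 (0.23 log units; within the scatter), hydrogen in place of hydroxy on an aromatic carbon.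

Compound 3 `CC(=O)c1cccn1[C@@H]1C[C@H]2O[C@@](C)([C@@H]1O)n1c3ccc(O)cc3c3c4c(c5c6ccccc6n2c5c31)C(=O)NC4` differs from compound 1 by 2-acetyl-1H-pyrrol-1-yl in place of acetamido on a saturated ring carbon. For the measured compounds named here, no measured step touches this change; the single step measured concerns another position and lies within the scatter. Nothing here points to a move beyond the scatter in this assay. Compound 3 is expected at 6000 nM (range 1500 nM to 25000 nM), close to the number of compound 1. This means an expected step of a 1.5-fold lower number from compound 1 to compound 3 (0.17 log units; within the scatter).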

Compound 3, half-maximal inhibitory concentration: 10500 nM
Compound 3: middle estimate off by 1.8-fold (0.24 log units), on the low side, within the range that was stated.
By their numbers in this assay, from the lowest: compounds 2, 1 and 3 (each within the scatter of the next, the first and the last beyond it).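

The exchange of acetamido for 2-acetyl-1H-pyrrol-1-yl on the saturated ring carbon gives a 1.2-fold higher number from compound 1 to compound 3 (0.08 log units; within the scatter) in this assay. This position therefore accepts a group with a five-membered aromatic ring and no hydrogen-bond donor without a step beyond the scatter. No measurement on hand accounts for this result. Still open, from the compounds shown here alone, is whether a primary amine or a carboxylic acid on this carbon would give a step beyond the scatter. Also open, going by these compounds, is how 2-acetyl-1H-pyrrol-1-yl behaves on the core of compound 2, which lacks the aromatic hydroxy.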